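The source may report more compounds than this note shows. Statements on the series, on what has been measured and on what is new or still open speak of the compounds shown alone.

Of the compounds shown here, two have been tested in a functional assay on SN12C cells (Homo sapiens) for inhibition, read by sulforhodamine B assay, with a stated time of 48 h (on this read-out lower numbers stand for higher toxicity in this test and higher numbers for lower toxicity in this test), so far. Compound 1 `O=C(Nc1cccc(-n2cc(-c3ccncc3)c(-c3ccc(Cl)c(O)c3)n2)c1)Nc1cccc(C(F)(F)F)c1` gives > 32500 nM, which is a limit of the assay rather than a number. Compound 2 `COc1cc(-c2nn(-c3cccc(NC(=O)Nc4cc(C(F)(F)F)cc(C(F)(F)F)c4)c3)cc2-c2ccncc2)ccc1Cl` gives > 50000 nM in this assay, again a limit and not a number. Both values shown are therefore limits, the limit of > 32500 nM in this assay, at which 1 of the 2 values shown sits, and (the limit of > 50000 nM in this assay, at which 1 of the 2 values shown sits), and compound 2 stands at one of them with nothing measurable to separate it from compound 1. Compound 3 `O=C(Nc1cccc(-n2cc(-c3ccncc3)c(-c3ccc(Cl)c(O)c3)n2)c1)Nc1cc(C(F)(F)F)cc(C(F)(F)F)c1` has not been tested; it differs from compound 2 by hydrogen in place of methyl on an oxygen on an aromatic ring. For the measured compounds named here, no measured step between two compounds is available here. Compound 1 already carries that same hydroxy group and sits at the limit of > 32500 nM in this assay, at which 1 of the 2 values shown sits, so compound 3 is expected to stay at a limit, a step of a number no higher from compound 2 to compound 3 (the limit leaves the size open) of no meaning beyond the scatter. The estimate for compound 3 in this assay is 50000 nM, within 20000 nM to 120000 nM.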

Compound 3, concentration lethal to 50% of the cells: > 50000 nM
Compound 3 was reported as a limit; the forecaster's own chance of this, stated with the estimate: 85%; the middle value sits exactly at the limit.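

Compound 3 is reported only as a limit, and compound 1 and compound 2 are limits too, so no step can be read from compound 3 to either of them. The compounds shown leave open where the actual values of all three lie in this assay, and whether changing methoxy to hydroxy or adding trifluoromethyl shifts them at all.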